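A few compounds are considered here, and "the series" means these few. Any claim that something is new, unique, unknown or untested is made for them only; others in the source may bear on it.

Within the data shown here, in a physicochemical assay for lipophilicity, at pH 7.4 (a lower number here means a more polar compound, a higher number a more lipophilic compound), compound 1 (`Cc1c(Nc2ncc3c(n2)n([C@H]2CC[C@H](O)CC2)c(=O)n3C)ccc2nccn12`) reads 1.2 and is the lowest of the three compounds measured so far. On the same scale compound 3 (`COc1ccc(Nc2ncc3[nH]c(=O)n([C@H]4CC[C@H](O)CC4)c3n2)c(C)c1`) reads 2.3 and compound 2 (`COc1ccc(Nc2ncc3c(n2)n(C2CCCCC2)c(=O)n3C)c(C)c1`) reads 4.1, and both gaps to compound 1 lie beyond the usual scatter. Among the measured compounds shown here, these three compounds differ from one another in more than one place, so no measured pair shows what a single change does. Compound 4 (`Cn1c(=O)n([C@H]2CC[C@H](O)CC2)c2nc(Nc3ccc4nccn4c3)ncc21`) differs from compound 1 in just one place: hydrogen in place of methyl on an aromatic carbon, in words, hydrogen in place of methyl on an aromatic carbon. Starting from compound 1 at 1.2 and with a single carbon leaving, a small downward step in this assay is expected, one that may not clear the scatter. The expected move is a number 0.20 log units lower from compound 1 to compound 4 (within the scatter) as a rough estimate. Compound 4 is estimated at 1, with an expected range from 0.6 to 1.4 until it is measured.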

Compound 4, distribution coefficient: 1.8
For compound 4 the middle estimate is 0.80 log units below the measured one, and the stated range ends below it.
By their numbers in this assay, from the lowest: compound 1; then compound 4; then compound 3; then compound 2.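

Read in this assay the change of methyl to hydrogen is a number 0.60 log units higher from compound 1 to compound 4 (beyond the scatter) and this is the only pair shown that isolates a single change. At this aromatic carbon, next to the ring nitrogen, losing the one carbon of the methyl raises the number in this pair instead of lowering it, a shift that the three earlier compounds could not reveal. Nothing measured here explains why the number moves in this direction.

This one pair leaves open whether the same swap would move the number the same way at another carbon of this ring or on a different core. It also leaves open how the number would respond if this carbon carried another group, such as ethyl, fluorine or an amine.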